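The source may hold more compounds than are shown below. What is called first, only, known or untested is meant among the compounds shown, and "the series" means these compounds.

Measured compounds:
- Compound 1, `O=[N+]([O-])c1c[nH]c(-c2nnc(-c3cc4cc(Cl)ccc4[nH]3)o2)c1`: 329000 nM
- Compound 2, `Cn1cc([N+](=O)[O-])cc1-c1nnc(-c2cc3ccccc3[nH]2)o1`: 109000 nM

Both compounds were tested in an ADME assay on Vero cells (Chlorocebus sabaeus) for cytotoxicity, read by MTT assay, with a stated time of 72 h; a higher number here means a weaker inhibitor, a lower number a stronger inhibitor. Among the measured compounds shown here, compound 2 gives 109000 nM, the lower of the two numbers known here. Compound 1 gives 329000 nM, a higher number, and the gap between the two lies beyond the usual scatter of this measurement. These two compounds differ from each other in more than one place, so their values can only be read side by side, not as a single step.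

The compound not yet measured is compound 3, `Cn1cc([N+](=O)[O-])cc1-c1nnc(-c2cc3cc(Cl)ccc3[nH]2)o1`. It differs from compound 2 in one place: chloro in place of hydrogen on an aromatic carbon. Everything else in the shared core is kept. For the measured compounds named here, no measured pair in this set shows the effect of exactly this change on its own, so the size of the step is open. Going by the values given here, with only two numbers known, the expectation for compound 3 is a small step, if any, from compound 2, lying within the scatter, with a slight lean toward a higher number: the step from compound 2 to compound 3 is estimated at a 1.4-fold higher number from compound 2 to compound 3 (0.14 log units; within the scatter). On that basis compound 3 is expected to give about 150000 nM in this assay, in a range from 60000 nM to 400000 nM.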

Compound 3, half-maximal inhibitory concentration: 743000 nM
For compound 3 the middle estimate is 5.0-fold (0.69 log units) below the measured one, outside the stated range (above it).
By their numbers in this assay, from the lowest: compound 2; then compound 1; then compound 3.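

In this assay, chloro in place of hydrogen on an aromatic carbon of the six-membered ring gives a 6.8-fold higher number from compound 2 to compound 3 (0.83 log units; beyond the scatter), so this single added atom clearly shifts the result when a methyl sits on the aromatic nitrogen. Compound 1 and compound 3 both carry the chloro and isolate a second change, methyl in place of hydrogen on an aromatic nitrogen, which gives a 2.3-fold higher number from compound 1 to compound 3 (0.35 log units; beyond the scatter) and shows that this change also raises the number, so a higher number is now linked to each of the two single changes and compound 3 has the highest number of the three. Nothing available here explains why either change has this effect.

The compounds shown cannot tell whether the chloro step would have the same size or direction with hydrogen rather than methyl on the aromatic nitrogen. On these data alone, it also remains open how the number would move with a different group on that aromatic carbon, such as fluoro, methoxy or an amine, or with a longer chain in place of the methyl on the nitrogen.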